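A few compounds are considered here, and "the series" means these few. Any claim that something is new, unique, unknown or untested is made for them only; others in the source may bear on it.

Of the compounds shown here, three sharing one core have been measured in a functional assay on HCT-116 cells (Homo sapiens) for cytotoxicity, read by MTT assay, with a stated time of 72 h; on this read-out higher numbers stand for weaker inhibition and lower numbers for stronger inhibition. Compound 1 `CCOc1cccc(/C=N/c2c(C)n(C)n(-c3ccccc3)c2=O)c1` gives 933000000 nM in this assay. Compound 2 `COc1ccc(/C=N/c2c(C)n(C)n(-c3ccccc3)c2=O)cc1` gives 575000000 nM. Compound 3 `Cc1c(/N=C/c2cccc(O)c2)c(=O)n(-c2ccccc2)n1C` gives 617000000 nM, the second highest of the three numbers, with compound 2 nearest and compound 1 furthest; both steps to it lie within the scatter: a 1.5-fold lower number from compound 1 to compound 3 (0.18 log units; within the scatter) and a 1.1-fold higher number from compound 2 to compound 3 (0.03 log units; within the scatter). Compound 4 `Cc1c(/N=C/c2ccccc2Cl)c(=O)n(-c2ccccc2)n1C` has not yet been measured. It differs from compound 3 in one place: 2-chlorophenyl in place of 3-hydroxyphenyl on a carbon with a double bond to nitrogen. The step from compound 2 to compound 3 bears most directly on this change: it too exchanges the aromatic ring on the carbon with a double bond to nitrogen, and it stayed within the scatter. The step from compound 1 to compound 3, also within the scatter, alters the same ring. On that basis no step beyond the scatter is expected in this assay. Compound 4 is therefore estimated at 620000000 nM, with a range from 250000000 nM to 1500000000 nM. The expected step is a 1.0-fold higher number from compound 3 to compound 4 (0.00 log units; within the scatter).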

Compound 4, half-maximal inhibitory concentration: 851000000 nM
The estimate for compound 4 lay 1.4-fold (0.14 log units) below the measured number; low and high end bracket the measured number.
By their numbers in this assay, from the lowest: compounds 2, 3, 4 and 1 (each within the scatter of the next).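

In this assay, among these compounds, the aromatic ring on the carbon with a double bond to nitrogen carries a chlorine for the first time, and 2-chlorophenyl in place of 3-hydroxyphenyl gives a 1.4-fold higher number from compound 3 to compound 4 (0.14 log units; within the scatter) while 2-chlorophenyl in place of 4-methoxyphenyl gives a 1.5-fold higher number from compound 2 to compound 4 (0.17 log units; within the scatter) in the same assay. Both steps lie within the scatter, so 2-chlorophenyl, with 0 hydrogen-bond donors and 0 hydrogen-bond acceptors, cannot be told apart at this position from 3-hydroxyphenyl, with 1 of each, or from 4-methoxyphenyl. No evidence is available that bears on this result.

Going by these compounds, it remains open whether any group on this ring can move the number beyond the scatter, for example an amine or a carboxylic acid. On these data alone, it is equally open whether replacing the phenyl on the shared core would do so.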